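Swapping a Pentyl Chain for a Fluorinated Ring

The source may report more compounds than this note shows. Statements on the series, on what has been measured and on what is new or still open speak of the compounds shown alone.

Three compounds have been measured in an ADME assay on PC-3 cells (Homo sapiens) for cytotoxicity, read by sulforhodamine B assay, with a stated time of 48 h, tested at 10 uM; a lower number here means less inhibition, a higher number more inhibition at the concentration tested (going by the name of the read-out):
Compound 1 `COc1nc2ccc(Br)cc2cc1C(c1ccccc1)n1cc(-c2ccccc2F)nn1` gives 13.4%.
Compound 2 `CCCCCc1cn(C(c2ccccc2)c2cc3cc(Br)ccc3nc2OC)nn1` gives 11.4%.
Compound 3 `COc1nc2ccc(Br)cc2cc1C(c1ccccc1)n1cc(CCO)nn1` gives 15.5%.

Compound 2 stands lowest of the three, but its nearest neighbour is compound 1, a number 2 percentage points lower from compound 1 to compound 2 (within the scatter), and even compound 3 is not far, a number 4.1 percentage points higher from compound 2 to compound 3 (within the scatter); all three sit within the scatter of one another.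

Compound 4 `COc1nc2ccc(Br)cc2cc1C(c1ccccc1)n1cc(-c2cccc(F)c2)nn1` differs from compound 2 in one place: 3-fluorophenyl in place of pentyl on an aromatic carbon. For the measured compounds named here, the most relevant measured step is the one from compound 1 to compound 2, where a 2-fluorophenyl gave way to pentyl and the number moved a number 2 percentage points lower from compound 1 to compound 2 (within the scatter). The step to compound 4 largely reverses that change, with the fluorine shifted on the ring, so no step beyond the scatter is expected in this assay. Compound 4 is therefore estimated at 13.5%, between 5% and 23%, a step of a number 2.1 percentage points higher from compound 2 to compound 4 (within the scatter).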

Compound 4, a percentage reported as inhibition, at one concentration (the size of the read-out at that concentration, not a potency): 14.6%
For compound 4 the middle estimate is 1.1 percentage points below the measured one; measured number inside the range.
By their numbers in this assay, from the lowest: compounds 2, 1, 4 and 3 (each within the scatter of the next).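

On this aromatic carbon, three swaps all end at 3-fluorophenyl: replacing pentyl gives a number 3.2 percentage points higher from compound 2 to compound 4 (within the scatter), replacing 2-hydroxyethyl gives a number 0.9 percentage points lower from compound 3 to compound 4 (within the scatter), and replacing 2-fluorophenyl gives a number 1.2 percentage points higher from compound 1 to compound 4 (within the scatter) in this assay. None of these steps leaves the scatter, so neither a ring in place of a chain nor a different fluorine place on the ring separates these compounds here. Nothing available explains this flat picture.

On these data alone, whether an amine or a carboxylic acid on this carbon would move the number beyond the scatter stays open. So does whether a change elsewhere on the shared core would.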